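Removing the Same Reactive Group a Second Time

The source may report more compounds than this note shows. Statements on the series, on what has been measured and on what is new or still open speak of the compounds shown alone.

Compound 1, `C=C(Br)C(=O)Nc1ccc(/C=C2\SC(=O)N(CC)C2=O)cc1`, in a functional assay on HeLa cells (Homo sapiens) for cytotoxicity, read by cell counting, with a stated time of 4 days (on this read-out higher numbers stand for weaker inhibition and lower numbers for stronger inhibition), gives 1400 nM.
Compound 2, `CCN1C(=O)S/C(=C\c2ccc(N)cc2)C1=O`, in this assay gives 108000 nM.
Compound 3, `C=C(Br)C(=O)Nc1ccc(/C=C2\SC(=O)N(Cc3ccc(C(C)(C)C)cc3)C2=O)cc1`, in this assay gives 2700 nM.

Compound 4, `CC(C)(C)c1ccc(CN2C(=O)S/C(=C\c3ccc(N)cc3)C2=O)cc1`, has not yet been measured in this assay. It is related to compound 3 by hydrogen in place of (1-bromoethenyl)carbonyl on a nitrogen on an aromatic ring. This change has been made once before among these compounds: compound 2 arises from compound 1 by hydrogen in place of (1-bromoethenyl)carbonyl on a nitrogen on an aromatic ring, and in this assay that step was a 77-fold higher number from compound 1 to compound 2 (1.89 log units; beyond the scatter). The two cores on which the change sits differ by 4-(tert-butyl)phenyl in place of methyl on a saturated chain carbon bound to an amide-type nitrogen in a ring; that difference on its own made a 1.9-fold higher number from compound 1 to compound 3 (0.29 log units; within the scatter), so the two starting points stand close together in this assay. The place of the change is described in identical words in both pairs, so the earlier step is the natural guide to the new one.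

In this assay the step to compound 4 is expected to be a 56-fold higher number from compound 3 to compound 4 (1.74 log units; beyond the scatter), a large rise in the number and thus a marked weakening, because a 77-fold higher number from compound 1 to compound 2 (1.89 log units; beyond the scatter) was large and well beyond the scatter. For the measured compounds named here, only a single measured example of this change exists, so the exact size remains uncertain. Compound 4 is therefore expected to give about 150000 nM in this assay, with a likely range from 50000 nM to 500000 nM.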

Compound 4, half-maximal inhibitory concentration: 53000 nM
Compound 4: middle estimate off by 2.8-fold (0.45 log units), on the high side, and the stated range covers the measured number.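

On its second core, the swap of (1-bromoethenyl)carbonyl for hydrogen again gives a large weakening in this assay (a 20-fold higher number from compound 3 to compound 4 (1.29 log units; beyond the scatter)). The direction of the change therefore carries from one core to the other, with the compound bearing the free amino group the weaker one in both pairs, but its size does not carry over exactly, as the two steps lie further apart than the scatter of such steps would explain: the same change on two cores in this assay, a 77-fold higher number (1.89 log units; beyond the scatter) from compound 1 to compound 2 and a 20-fold higher number (1.29 log units; beyond the scatter) from compound 3 to compound 4, 3.9-fold (0.59 log units) apart, beyond the scatter of two such steps. For the compounds shown here, these two pairs show only that the earlier step is a good guide to the direction and a rougher guide to the size; they give no general rule for other cores, and they do not show why the size differs.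

The compounds shown leave open whether the bromine or the rest of the group matters, a question that a plain acetyl group or an unsubstituted acryloyl group on the same nitrogen could help to settle. They also leave open how large the step would be on a core with a different group on the ring nitrogen, such as a longer chain or one ending in a carboxylic acid.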